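The compounds below may be only part of what the source reports. "The series", "measured", "known", "first", "only" and "open" are said of these compounds alone.

Measured compounds:
- compound 1 `CCSc1sc(-n2nc(C)c(Cc3ccccc3[N+](=O)[O-])c2C(=O)O)nc1-c1ccc(Cl)c(Cl)c1`: 59000 nM
- compound 2 `COc1ccc(C)cc1-c1c(C)nn(-c2nc(-c3ccc(Cl)c(Cl)c3)c(SC(C)C)s2)c1C(=O)O`: 9500 nM

Both compounds were tested in a functional assay on BJAB cells (Homo sapiens) for antiproliferative activity, with a stated time of 4 days; on this read-out lower numbers stand for an effect already at smaller amounts and higher numbers for an effect only at larger amounts of compound. Compound 1 gives 59000 nM there, while compound 2 gives 9500 nM, the lower of the two numbers, and this gap lies beyond the usual scatter. Compound 3 `Cc1nn(-c2nc(-c3ccc(Cl)c(Cl)c3)c(SC(C)C)s2)c(C(=O)O)c1-c1cccc(Cl)c1C` has not yet been measured in this assay. It differs from compound 2 in a single place: 3-chloro-2-methylphenyl in place of 2-methoxy-5-methylphenyl on an aromatic carbon. For the measured compounds named here, no measured pair shows a change of this kind, so the expected size of the step from compound 2 to compound 3 is uncertain; the expected result is a step of about a 1.2-fold lower number from compound 2 to compound 3 (0.07 log units; within the scatter), which would keep compound 3 close to compound 2 and well clear of the number seen for compound 1. For compound 3 the estimated value in this assay is 8000 nM, with a likely range from 2500 nM to 25000 nM.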

Compound 3, half-maximal effective concentration: 5100 nM
Compound 3: middle estimate off by 1.6-fold (0.20 log units), on the high side; the range from low to high includes it.
By their numbers in this assay, from the lowest: compounds 3 and 2 (each within the scatter of the next); then compound 1.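

In this assay, putting 3-chloro-2-methylphenyl in place of 2-methoxy-5-methylphenyl on this aromatic carbon gives a 1.9-fold lower number from compound 2 to compound 3 (0.27 log units; within the scatter), so the two substituted phenyl groups cannot be told apart here. This single pair shows that, at this position, the number holds when the methoxy group and its hydrogen-bond acceptor leave and a chlorine enters. No measured evidence here accounts for this result.

Several ring substituents change together in this swap, so the pair cannot show what each one contributes on its own. It also leaves open whether this position would accept a phenyl ring carrying an amine or a carboxylic acid, or a plain methyl group with no ring at all.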